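The source may report more compounds than this note shows. Statements on the series, on what has been measured and on what is new or still open speak of the compounds shown alone.

Values so far in a functional assay on MCF-A cells (Homo sapiens) for cytotoxicity (on this read-out lower numbers stand for stronger inhibition of growth and higher numbers for weaker inhibition of growth), are these:
- compound 1 `COc1ccc(C2=C(c3ccc(SC)cc3)CC3CCCN3C2=O)cc1O` gives 5000 nM
- compound 2 `CSc1ccc(C2=C(c3ccc(F)c(F)c3)C(=O)N3CCCC3C2)cc1` gives 800 nM

Compound 2 holds the lower of these two numbers. The gap between them comes from a single change on a double-bonded ring carbon, where 3,4-difluorophenyl stands in place of 3-hydroxy-4-methoxyphenyl. Compound 3 `CSc1ccc(C2=C(c3ccc(C)c(C)c3)C(=O)N3CCCC3C2)cc1` changes that same place again and keeps the rest of compound 2 untouched, with 3,4-dimethylphenyl in place of 3,4-difluorophenyl on a double-bonded ring carbon as the only difference.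

Among the measured compounds shown here, one measured step bears on this, a 6.3-fold lower number from compound 1 to compound 2 (0.80 log units; beyond the scatter) and it shows that a change at this place can move the number by a modest amount. That step, however, removed a different group. For the measured compounds named here, no measured pair compares 3,4-dimethylphenyl with 3,4-difluorophenyl, so no clear direction can be expected, and a large shift has no support either. The expected step is small, a 1.3-fold higher number from compound 2 to compound 3 (0.10 log units; within the scatter) and it leans only slightly towards a higher number. For compound 3 the estimate is 1000 nM in this assay with 300 nM to 3500 nM as its expected range.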

Compound 3, concentration for 50% growth inhibition: 800 nM
For compound 3 the middle estimate is 1.3-fold (0.10 log units) above the measured one; low and high end bracket the measured number.
By their numbers in this assay, from the lowest: compounds 2 and 3 (each within the scatter of the next); then compound 1.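

In this assay, replacing 3,4-difluorophenyl with 3,4-dimethylphenyl on the double-bonded ring carbon gives no change at the digits printed from compound 2 to compound 3 (within the scatter) and so reveals no preference between these two groups at this position. Set beside the earlier step, a 6.3-fold lower number from compound 1 to compound 3 (0.80 log units; beyond the scatter) matches a 6.3-fold lower number from compound 1 to compound 2 (0.80 log units; beyond the scatter) in size, which shows that among these compounds the lower number reached on leaving 3-hydroxy-4-methoxyphenyl does not require fluorine on the incoming ring. No supporting measurement is available to explain either the lack of a difference or the size of these steps.

The compounds shown leave open whether this position would tolerate a phenyl ring carrying an amine or a carboxylic acid as readily as it tolerates 3,4-difluorophenyl and 3,4-dimethylphenyl. They also do not separate the hydroxy group from the methoxy group of 3-hydroxy-4-methoxyphenyl, as the two leave together in each step, so a ring with only one of them, such as 4-methoxyphenyl, would be needed to tell which one goes with the higher number of compound 1.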